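A Methyl Added Beside the Amide Nitrogen

The source may hold more compounds than are shown below. What is called first, only, known or untested is meant among the compounds shown, and "the series" means these compounds.

Three measured compounds share one core and differ only in the short chain on the amide-type nitrogen. Compound 1 `CCn1c(C(=O)N[C@@H](C)CO)ccc1C(CC)(CC)c1ccc(OCS(=O)(=O)c2ccccc2)c(C)c1` carries 1-(hydroxymethyl)ethyl there, compound 2 `CCn1c(C(=O)NCCO)ccc1C(CC)(CC)c1ccc(OCS(=O)(=O)c2ccccc2)c(C)c1` carries 2-hydroxyethyl, and compound 3 `CCn1c(C(=O)NCC(=O)O)ccc1C(CC)(CC)c1ccc(OCS(=O)(=O)c2ccccc2)c(C)c1` carries carboxymethyl. In a functional assay on MCF7 cells (Homo sapiens) for antiproliferative activity, read by MTT assay, with a stated time of 24 h (a higher number here means a weaker inhibitor, a lower number a stronger inhibitor), compound 1 gives 10800 nM, compound 2 gives 15500 nM, and compound 3 gives 33100 nM. Two steps lie beyond the scatter: a 3.1-fold higher number from compound 1 to compound 3 (0.49 log units; beyond the scatter) and a 2.1-fold higher number from compound 2 to compound 3 (0.33 log units; beyond the scatter), the latter being the change (carboxy in place of hydroxymethyl on a saturated chain carbon bound to an amide-type nitrogen). The third step, a 1.4-fold lower number from compound 2 to compound 1 (0.16 log units; within the scatter), is the change methyl in place of hydrogen on a saturated chain carbon bound to an amide-type nitrogen and a saturated chain carbon and stays within the scatter.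

Compound 4 `CCn1c(C(=O)N[C@H](C)C(=O)O)ccc1C(CC)(CC)c1ccc(OCS(=O)(=O)c2ccccc2)c(C)c1` has not yet been measured. It stands to compound 3 as compound 1 stands to compound 2: the change is methyl in place of hydrogen on a saturated chain carbon bound to an amide-type nitrogen and a carbonyl carbon. This is the same kind of change, not the same one. The carbon that gains the methyl is bound to a saturated chain carbon in compound 1 but to a carbonyl carbon in compound 4. An equally small step is expected here, a 1.3-fold lower number from compound 3 to compound 4 (0.12 log units; within the scatter). Compound 4 is therefore estimated at 25000 nM in this assay, likely between 12000 nM and 55000 nM, because the matching earlier step a 1.4-fold lower number from compound 2 to compound 1 (0.16 log units; within the scatter) stayed within the scatter. The measured value will show whether this holds.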

Compound 4, half-maximal inhibitory concentration: > 50000 nM
Compound 4: no number, only a limit; the forecaster's own chance of this, stated with the estimate: 10%; middle value at least 2.0-fold (0.30 log units) away from the limit.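

Compound 4 gives > 50000 nM in this assay, which is a limit of the assay and not a number, and it is the only reading of its kind among these compounds: the limit of > 50000 nM in this assay, at which 1 of the 4 values shown sits.

The steps to compound 4 are therefore floors: an at least 1.5-fold higher number from compound 3 to compound 4 (0.17 log units; that floor lies within the scatter), then an at least 3.2-fold higher number from compound 2 to compound 4 (0.50 log units; beyond the scatter), and an at least 4.6-fold higher number from compound 1 to compound 4 (0.66 log units; beyond the scatter), so the last two already lie beyond the scatter while the first does not. Carrying the methyl from the chain of compound 2 to the chain of compound 3 shows no clear agreement or disagreement between the two cases, and it does not show that the change behaves the same way on both: the same change on two cores in this assay, a 1.4-fold lower number (0.16 log units; within the scatter) from compound 2 to compound 1 and an at least 1.5-fold higher number (0.17 log units; that floor lies within the scatter) from compound 3 to compound 4; the limit leaves it open whether they differ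

From the compounds shown here alone, the true size of the methyl step on the carboxy-bearing chain stays unknown, and only a measured number for compound 4 could fix it, since a floor within the scatter cannot separate a small step from a large one. The compounds shown also leave open how a longer chain in place of the methyl, or an amine in place of the carboxylic acid, would read in this assay.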